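The source may report more compounds than this note shows. Statements on the series, on what has been measured and on what is new or still open speak of the compounds shown alone.

Compound 1 `O=c1cc(-c2ccccc2)oc2cc(N3COc4c(Br)cccc4C3)ccc12` gives 19.5% in a functional assay on MCF7 cells (Homo sapiens) for inhibition, read by MTT assay, with a stated time of 48 h, tested at 60 ug/mL; a lower number here means less inhibition of growth, a higher number more inhibition of growth at the concentration tested.
Compound 2 `O=c1cc(-c2ccccc2)oc2cc(N3COc4c(Cl)cc(Cl)cc4C3)ccc12` gives 68.8%.
Compound 3 `O=c1cc(-c2ccccc2)oc2cc(N3COc4c(Br)cc(Br)cc4C3)ccc12` gives 26.5%.

Compound 1 stands at the low end of these three numbers: its value and that of compound 3 lie within the scatter of each other, while compound 2 sits well beyond the scatter above it. Compound 4 `O=c1cc(-c2ccccc2)oc2cc(N3COc4c(cccc4[N+](=O)[O-])C3)ccc12` differs from compound 1 in one place, (nitro in place of bromo on an aromatic carbon). Among the measured compounds shown here, the only measured step, a number 7 percentage points higher from compound 1 to compound 3 (within the scatter), adds a bromo rather than exchanging one for a nitro, so no measured step bears directly on this change. Compound 4 is therefore expected to remain near compound 1, with a wide range, at 28% (10% to 50%), a step of a number 8.5 percentage points higher from compound 1 to compound 4 (within the scatter).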

Compound 4, percent growth inhibition at one concentration: 15.7%
Beside the measured number, compound 4's estimate is 12.3 percentage points above it; the range from low to high includes it.
By their numbers in this assay, from the lowest: compounds 4, 1 and 3 (each within the scatter of the next, the first and the last beyond it); then compound 2.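

In this assay, exchanging the group itself at this aromatic carbon, rather than adding a bromo elsewhere on the ring, gives a number 3.8 percentage points lower from compound 1 to compound 4 (within the scatter). Bromo and nitro therefore cannot be told apart here, although the nitro brings two hydrogen-bond acceptors and the bromo none. Nothing available explains this result.

As far as these compounds go, what an amine, a carboxylic acid or a single chloro would give at this carbon stays open. From the compounds shown here alone, it also remains open whether nitro would read the same with a second group on that ring.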